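One Stereocentre Flipped: What Compound 4 May Show

A few compounds are considered here, and "the series" means these few. Any claim that something is new, unique, unknown or untested is made for them only; others in the source may bear on it.

compound 1 `Cc1cc(=O)c2c(O)cc(OCC3CO3)cc2o1` gives 18300 nM
compound 2 `Cc1cc(=O)c2c(OC[C@H]3CO3)cc(OC[C@H]3CO3)cc2o1` gives 229000 nM
compound 3 `Cc1cc(=O)c2c(OC[C@@H]3CO3)cc(OC[C@H]3CO3)cc2o1` gives 12100 nM

In a functional assay on HCT-15 cells (Homo sapiens) for antiproliferative activity, with a stated time of 48 h (a lower number here means a stronger inhibitor, a higher number a weaker inhibitor), compound 2 gives 229000 nM, the highest number of the three and so the weakest inhibitor shown here. Compound 4 `Cc1cc(=O)c2c(OC[C@H]3CO3)cc(OC[C@@H]3CO3)cc2o1` has not yet been measured. Its structure is related to that of compound 2 as follows: the two compounds have the same atoms and bonds and differ only in configuration as drawn: 1 of 2 stereo elements differ; a stereocentre at a saturated ring carbon is drawn R in compound 2 and S in compound 4. Going by the values given here, the one measured step that bears on this is a 19-fold lower number from compound 2 to compound 3 (1.28 log units; beyond the scatter). That large change is due to the fact that compounds 2 and 3 differ only in the configuration as drawn. Among the compounds with values here, a single flip can therefore matter a great deal, but compound 4 flips the other stereocentre, and no measurement yet shows how much that one counts. Since compound 3 reached 12100 nM with one flip, a lower number is also expected for compound 4 , though probably by a smaller margin and with wide uncertainty. The expected change is a 4.6-fold lower number from compound 2 to compound 4 (0.66 log units; beyond the scatter). Compound 4 is estimated at 50000 nM, within a range of 12000 nM to 230000 nM.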

Compound 4, half-maximal inhibitory concentration: 9590 nM
Beside the measured number, compound 4's estimate is 5.2-fold (0.72 log units) above it; measured number outside the range, below it.
By their numbers in this assay, from the lowest: compounds 4, 3 and 1 (each within the scatter of the next); then compound 2.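

Either stereocentre of compound 2 turns out to matter: in this assay the second flip also gives a large step, a 24-fold lower number from compound 2 to compound 4 (1.38 log units; beyond the scatter), just as the first gave a 19-fold lower number from compound 2 to compound 3 (1.28 log units; beyond the scatter). Nothing but configuration can account for this new step, because the structures leave only one explanation: the fact that compounds 2 and 4 differ only in the configuration as drawn. Compound 3 and compound 4 are mirror images, yet they cannot be told apart here, with a 1.3-fold lower number from compound 3 to compound 4 (0.10 log units; within the scatter), so among these compounds it is compound 2 that stands alone, with both of these stereocentres drawn R.

The compounds shown leave open how the form with both stereocentres drawn S would behave. They also leave open whether this sensitivity to configuration would survive if an amine or a longer chain were placed on the shared core.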